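The source may report more compounds than this note shows. Statements on the series, on what has been measured and on what is new or still open speak of the compounds shown alone.

Compound 1 `CCC1(Cc2ccccc2)OS(=O)(=O)C=C1OCc1ccccc1Cl` is the most toxic of three measured compounds in an ADME assay on HEL cells (Homo sapiens) for cytotoxicity, with a stated time of 3 days (on this read-out lower numbers stand for higher toxicity in this test and higher numbers for lower toxicity in this test), where compound 1 gives 38000 nM. Compound 3 `CCC1(Cc2ccccc2)OS(=O)(=O)C=C1OCc1ccc(C(F)(F)F)cc1` gives 99000 nM in this assay, and compound 2 `CC(C)CC1(Cc2ccccc2)OS(=O)(=O)C=C1OCc1ccccc1` gives 102000 nM; both of these gaps from compound 1 lie beyond the usual scatter. The unmeasured compound 4 `C=CCOC1=CS(=O)(=O)OC1(CC)Cc1ccccc1` differs from compound 1 in one place: vinyl in place of 2-chlorophenyl on a saturated chain carbon bound to an oxygen on an unsaturated carbon. Among the measured compounds shown here, no pair of measured compounds shows this particular change, so its size can only be guessed. Since the two compounds that carry other groups at this position both read higher than compound 1, a modest rise in the number, meaning somewhat lower toxicity, is expected for compound 4, giving an estimated 70000 nM (range 30000 nM to 180000 nM) and an expected step of a 1.8-fold higher number from compound 1 to compound 4 (0.27 log units; within the scatter).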

Compound 4, half-maximal cytotoxic concentration: > 200000 nM
Compound 4: a limit, no number; the forecaster's own chance of this, stated with the estimate: 10%; middle value at least 2.8-fold (0.45 log units) away from the limit.
By their numbers in this assay, from the lowest: compound 1; then compounds 3 and 2 (each within the scatter of the next). At a limit, above all of these: compound 4.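

Compound 4 gives > 200000 nM in this assay, which is a limit of the assay and not a number. Among the compounds shown here, putting vinyl in place of 2-chlorophenyl, with the rest of compound 1 unchanged, gives an at least 5.2-fold higher number from compound 1 to compound 4 (0.72 log units; beyond the scatter), the first one-place comparison at this position, and it shows that the swap lowers toxicity in this test. How far the true value lies past this point cannot be read: the limit of > 200000 nM in this assay, at which 1 of the 4 values shown sits.

Going by these compounds, whether removing the aromatic ring or the chlorine matters more remains open. So does how an amine or a longer chain would read at this place.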